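This account rests on a few compounds, and the source may have more. Where it says the series, first, only, none or still open, it means among the compounds named here.

Compound 2 `COc1cccc(NC(=O)c2c(O)c3cccnc3n(-c3ccccc3)c2=O)c1` gives the higher of the two numbers measured in a functional assay on the whole organism for inhibition, with Rattus norvegicus as the target, read by cytopathic effect and paw edema, at a dose of 100 mg/kg by the oral route (on this read-out lower numbers stand for less inhibition and higher numbers for more inhibition at the one dose given (going by the name of the read-out)), at 20.7%. Compound 1 `O=C(Nc1ccc([N+](=O)[O-])cc1)c1c(O)c2cccnc2n(-c2ccccc2)c1=O` gives -25.8% in this assay. Compound 3 `Cc1ccccc1NC(=O)c1c(O)c2cccnc2n(-c2ccccc2)c1=O` has not been measured; it differs from compound 2 at one place: 2-methylphenyl in place of 3-methoxyphenyl on an amide-type nitrogen. Among the measured compounds shown here, the only measured step also alters the group on the amide-type nitrogen, a number 46.5 percentage points higher from compound 1 to compound 2 (beyond the scatter), yet it swaps a different pair of groups, so it gives only a loose guide. The step to compound 3 is therefore expected to be small, a number 8.7 percentage points lower from compound 2 to compound 3 (within the scatter). For compound 3 an inhibition of 12% is estimated, within -18% to 42%.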

Compound 3, a percentage reported as inhibition, in the whole organism at one dose (the size of the read-out at that dose, not a potency): 9.8%
Compound 3: middle estimate off by 2.2 percentage points, on the high side; the measured number falls inside the stated range.
By their numbers in this assay, from the lowest: compound 1; then compound 3; then compound 2.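

In this assay, 3-methoxyphenyl is not the only replacement for 4-nitrophenyl on the amide-type nitrogen that pays off: 2-methylphenyl also gives a number 35.6 percentage points higher from compound 1 to compound 3 (beyond the scatter) and so stands well clear of the nitro compound. The two replacements are still not interchangeable, with a number 10.9 percentage points lower from compound 2 to compound 3 (beyond the scatter) as a modest but real drop. No measurement at hand accounts for either step.

The compounds shown cannot separate the change of group from the change in where it sits on the phenyl ring. Going by these compounds, how an amine, a carboxylic acid or a longer chain would read at this nitrogen also stays open.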